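Moving the Fluorine on the Sulfonyl Aryl Ring

This account rests on a few compounds, and the source may have more. Where it says the series, first, only, none or still open, it means among the compounds named here.

Compound 3 `COc1ccccc1C(=O)NCc1ccc(CNS(=O)(=O)c2cccc(F)c2)cc1` gives 1000 nM in an assay on MDA-MB-231 cells for displacement of a labelled ligand from C-X-C chemokine receptor type 4 (Homo sapiens), read by fluorescence and microscopy, with stated times of 10 min and 30 min (on this read-out higher numbers stand for an effect only at larger amounts of compound and lower numbers for an effect already at smaller amounts), the higher of the two numbers measured there; the nearest compound, compound 2 `Cc1ccccc1C(=O)NCc1ccc(CNS(=O)(=O)c2ccc(F)cc2)cc1`, gives 10 nM, a gap well beyond the scatter. Compound 1 `COc1ccccc1C(=O)NCc1ccc(CNS(=O)(=O)c2cccc3ccccc23)cc1` reports only a limit, > 1000 nM. Going by the values given here, the single measured step, a number no higher from compound 1 to compound 3 (the limit leaves the size open), is of unreadable size because of the limit of > 1000 nM in this assay, at which 1 of the 3 values shown sits. Compound 4 `COc1ccccc1C(=O)NCc1ccc(CNS(=O)(=O)c2ccc(F)cc2)cc1` differs from compound 3 by 4-fluorophenyl in place of 3-fluorophenyl on a sulfonyl sulfur. Among the compounds with values here, no measured step moves the fluorine on its own, and compound 2 differs from compound 4 in two places, so its value shows only that a (4-fluorophenyl)sulfonyl group can go with a low number. Compound 4 is therefore expected to improve modestly, a 5.0-fold lower number from compound 3 to compound 4 (0.70 log units; beyond the scatter), with an estimate of 200 nM lying between 30 nM and 1000 nM.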

Compound 4, effective concentration (reported as EC, without a stated level of effect): 100 nM
Compound 4: the middle estimate sits 2.0-fold (0.30 log units) above what was measured; the range from low to high includes it.
By their numbers in this assay, from the lowest: compound 2; then compound 4; then compound 3.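

In this assay, going by these compounds alone, moving the fluorine alone gives a 10-fold lower number from compound 3 to compound 4 (1.00 log units; beyond the scatter), so this place on the sulfonyl sulfur matters in its own right, which no earlier step could show. Methoxy in place of methyl on an aromatic carbon gives a 10-fold higher number from compound 2 to compound 4 (1.00 log units; beyond the scatter), so the (4-fluorophenyl)sulfonyl group alone does not account for the low number of compound 2. The 4-fluorophenyl group in place of naphthalen-1-yl gives an at least 10-fold lower number from compound 1 to compound 4 (1.00 log units; beyond the scatter), a step that rests on a limit for its first compound: the limit of > 1000 nM in this assay, at which 1 of the 4 values shown sits.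

As far as these compounds go, how the 3-fluorophenyl group behaves alongside the methyl remains open. So does whether a chlorine or a nitrile could stand in for the fluorine.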